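The source may hold more compounds than are shown below. What is called first, only, known or untested is meant among the compounds shown, and "the series" means these compounds.

Measured so far:
Compound 1 `CC1=CC[C@H](C(C)(C)NC(=S)N/N=C/c2ccc(O)cc2)CC1` gives > 100000 nM in an ADME assay on Vero cells (Chlorocebus sabaeus) for inhibition, read by sulforhodamine B assay, with a stated time of 48 h (on this read-out higher numbers stand for weaker inhibition of growth and lower numbers for stronger inhibition of growth), and this is a limit of the assay rather than a number.
Compound 2 `COc1cc(/C=N/NC(=S)NC(C)(C)[C@H]2CC=C(C)CC2)ccc1O` gives 19700 nM in this assay.

Among the measured compounds shown here, compound 1 therefore stands at the limit: the assay reports only that its number lies beyond what it can read, so its true position is known only as a bound (the limit of > 100000 nM in this assay, at which 1 of the 2 values shown sits). For the measured compounds named here, the one measured step, an at least 5.0-fold lower number from compound 1 to compound 2 (0.70 log units; beyond the scatter), is the only comparison available, and because it starts from the limit of > 100000 nM in this assay, at which 1 of the 2 values shown sits, its true size is itself known only as a bound.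

Compound 3 `CC1=CC[C@H](C(C)(C)NC(=S)N/N=C/c2ccc[nH]2)CC1` is to be measured in this assay. The change from compound 1 is 1H-pyrrol-2-yl in place of 4-hydroxyphenyl on a carbon with a double bond to nitrogen. Going by the values given here, no measured step touches this aromatic ring, so the methoxy step says nothing direct about a pyrrole swap. With compound 1 at the limit, the expectation for compound 3 is 100000 nM, with a range from 30000 nM to 300000 nM, which means an expected step of a number no higher from compound 1 to compound 3 (the limit leaves the size open), and a sizeable chance that the assay again reports only a limit.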

Compound 3, concentration for 50% growth inhibition: 20500 nM
Compound 3: middle estimate off by 4.9-fold (0.69 log units), on the high side; the measured number lies below the stated range.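

In this assay the aromatic ring on the carbon with a double bond to nitrogen can be exchanged outright, not only decorated: 1H-pyrrol-2-yl in place of 4-hydroxyphenyl gives an at least 4.8-fold lower number from compound 1 to compound 3 (0.68 log units; beyond the scatter), which means stronger inhibition of growth. The earlier step showed only a methoxy added to the 4-hydroxyphenyl ring, whereas this change replaces the whole ring with a five-membered aromatic ring and still gives a measured number rather than a limit, with one hydrogen-bond donor on each side of the swap. Compound 1 stands at a limit, so the real size of this step is known only as a bound, because the starting point is not a number: the limit of > 100000 nM in this assay, at which 1 of the 3 values shown sits.

The swap changes several things at once, removing the hydroxyl, shrinking the ring from six members to five and bringing a nitrogen into it, and the compounds shown cannot separate these. A plain phenyl ring would test the hydroxyl alone, while a furan-2-yl ring, with oxygen in place of the ring nitrogen, would test whether the nitrogen and its hydrogen matter.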